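The compounds below may be only part of what the source reports. "The series", "measured", "known", "first", "only" and "open" are said of these compounds alone.

Three compounds were tested in a functional assay on HeLa cells (Homo sapiens) for antiproliferative activity, read by resazurin assay; on this read-out higher numbers stand for weaker inhibition and lower numbers for stronger inhibition. Compound 1, `CCSC(=S)SCC(=O)c1ccccc1OC`, gives 15800 nM in this assay, the highest of the three numbers. Compound 2, `CCSC(=S)SCC(=O)c1ccc(OC)cc1`, gives 2510 nM, and compound 3, `CCSC(=S)SCC(=O)c1ccc(OC)c(OC)c1`, gives 5010 nM. Compound 1 and compound 2 are built from the same atoms joined differently, and the difference between the two cores is not broken down here. Compound 3 differs from compound 2 in one place, (methoxy in place of hydrogen on an aromatic carbon), and that change gave a 2.0-fold higher number from compound 2 to compound 3 (0.30 log units; within the scatter), so the two numbers are not told apart by this assay.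

Compound 4, `CCSC(=S)SCC(=O)c1cc(OC)ccc1OC`, has not yet been measured. It differs from compound 1 by methoxy in place of hydrogen on an aromatic carbon. Among the measured compounds shown here, this is the same kind of change as the one from compound 2 to compound 3, but not the same: in compound 3 the entering methoxy sits ortho to a methoxy group and meta to a group of 9 heavy atoms, whereas in compound 4 it sits meta to a group of 9 heavy atoms and para to a methoxy group. Since the same kind of change from compound 2 to compound 3 gave a 2.0-fold higher number from compound 2 to compound 3 (0.30 log units; within the scatter), the step from compound 1 to compound 4 is expected to be about a 1.0-fold higher number from compound 1 to compound 4 (0.01 log units; within the scatter). Compound 4 is therefore estimated at 16000 nM in this assay, most likely between 6000 nM and 40000 nM.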

Compound 4, half-maximal inhibitory concentration: 15800 nM
Compound 4: middle estimate off by 1.0-fold (0.01 log units), on the high side; the range from low to high includes it.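

In this assay, putting methoxy in place of hydrogen on the aromatic carbon that lies meta to a group of 9 heavy atoms and para to a methoxy group gave no change at the digits printed from compound 1 to compound 4 (within the scatter) in this series. Set beside the earlier case, the same kind of change gives results on the two cores that this assay cannot tell apart: the same change on two cores in this assay, a 2.0-fold higher number (0.30 log units; within the scatter) from compound 2 to compound 3 and no change at the digits printed (within the scatter) from compound 1 to compound 4, 2.0-fold (0.30 log units) apart, within the scatter of two such steps. This shows that the two steps agree as far as the measurements can say, but it does not show that methoxy makes no difference wherever it is added, since each step is a single pair of compounds, the entering group sits at a different place on the ring in each, and two cores are too few to predict what the change would do on a third.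

The compounds shown leave open whether a different group on the ring, such as a fluorine atom, a hydroxyl group or an amine, would shift the number by more than the scatter. They also leave open what a longer chain in place of the ethyl group would do on these cores.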